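Removing the aminopropyl arm from a tertiary sulfonamide

A few compounds are considered here, and "the series" means these few. Any claim that something is new, unique, unknown or untested is made for them only; others in the source may bear on it.

Compound 1, `COCCNS(=O)(=O)c1ccc(C)c(C#Cc2cc(Cl)ccc2OCC(=O)O)c1`, in an assay on CHO cells for displacement of a labelled ligand from prostaglandin D2 receptor 2 (Homo sapiens), read by scintillation counting (on this read-out higher numbers stand for weaker inhibition and lower numbers for stronger inhibition), gives 3.6 nM.
Compound 2, `CNS(=O)(=O)c1ccc(C)c(C#Cc2cc(Cl)ccc2OCC(=O)O)c1`, gives 10 nM.
Compound 3, `Cc1ccc(S(=O)(=O)N(C)CCCN(C)C)cc1C#Cc1cc(Cl)ccc1OCC(=O)O`, gives 287 nM.

Compound 3 stands highest of the three numbers in this assay; its nearest neighbour is compound 2, and the gap to compound 1 is the widest shown. The steps leading to it are both large: a 29-fold higher number from compound 2 to compound 3 (1.46 log units; beyond the scatter) and an 80-fold higher number from compound 1 to compound 3 (1.90 log units; beyond the scatter). By contrast a 2.8-fold higher number from compound 1 to compound 2 (0.44 log units; beyond the scatter) is only a modest change among the secondary sulfonamides.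

Compound 4, `Cc1ccc(S(=O)(=O)N(C)C)cc1C#Cc1cc(Cl)ccc1OCC(=O)O`, is not yet measured. It differs from compound 3 in one place: hydrogen in place of 2-(dimethylamino)ethyl on a saturated chain carbon bound to a sulfonamide nitrogen. The same difference, cut one bond further out, reads 3-(dimethylamino)propyl to methyl, so compound 4 carries a dimethylamino on the sulfonyl sulfur.

The step that bears on this most directly is a 29-fold higher number from compound 2 to compound 3 (1.46 log units; beyond the scatter), since it adds a 3-(dimethylamino)propyl to a sulfonamide nitrogen and brings a large rise. Going by the values given here, compound 4 keeps the methyl on that nitrogen, and no measured pair shows what a single methyl in place of hydrogen there does, so the return is not expected to be complete. A large fall in the number is expected, a 9.6-fold lower number from compound 3 to compound 4 (0.98 log units; beyond the scatter), and compound 4 is estimated at 30 nM, within 8 nM to 120 nM.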

Compound 4, inhibition constant: 5 nM
Compound 4: the middle estimate sits 6.0-fold (0.78 log units) above what was measured; the measured number lies below the stated range.
By their numbers in this assay, from the lowest: compounds 1, 4 and 2 (each within the scatter of the next, the first and the last beyond it); then compound 3.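

In this assay, taking away the 2-(dimethylamino)ethyl gives a 57-fold lower number from compound 3 to compound 4 (1.76 log units; beyond the scatter) and so ties the high number of compound 3 to that arm, not to the tertiary sulfonamide nitrogen as such. A tertiary sulfonamide without the arm stays level with the secondary ones: methyl in place of hydrogen on the sulfonamide nitrogen gives a 2.0-fold lower number from compound 2 to compound 4 (0.30 log units; within the scatter) and dimethylamino in place of (2-methoxyethyl)amino on the sulfonyl sulfur gives a 1.4-fold higher number from compound 1 to compound 4 (0.14 log units; within the scatter) with both steps lying within the scatter. No measured property is at hand that would account for the size of the arm's effect.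

The compounds shown leave open whether the rise in compound 3 belongs to the terminal dimethylamino or to the length of the chain, a question that a propyl chain ending in a methoxy or a hydroxyl group in place of that amine would address. They also leave open how far the sulfonamide nitrogen accepts larger groups without an amine, such as an ethyl, or a morpholine ring on the sulfonyl sulfur.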